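Adding a second chloro to compound 2

This account rests on a few compounds, and the source may have more. Where it says the series, first, only, none or still open, it means among the compounds named here.

In a functional assay on RT-112 cells (Homo sapiens) for antiproliferative activity, read by MTT assay, with a stated time of 72 h (a lower number here means a stronger inhibitor of growth, a higher number a weaker inhibitor of growth), compound 1 `COc1cc(Nc2ncnc3c(NC(=O)Nc4cccc(C)c4C)cccc23)cc(OC)c1` gives 5910 nM, and compound 2 `COc1cc(Nc2ncnc3c(NC(=O)Nc4ccc(Cl)cc4)cccc23)cc(OC)c1` gives 2490 nM, the lower of the two numbers. Compound 3 `COc1cc(Nc2ncnc3c(NC(=O)Nc4ccc(Cl)c(Cl)c4)cccc23)cc(OC)c1` differs from compound 2 by one substitution, chloro in place of hydrogen on an aromatic carbon, which turns 4-chlorophenyl into 3,4-dichlorophenyl. Among the compounds with values here, only one measured step bears on this, and only loosely. That step, a 2.4-fold lower number from compound 1 to compound 2 (0.38 log units; beyond the scatter), is modest but beyond the scatter, and it brought in 4-chlorophenyl in place of 2,3-dimethylphenyl. Within the data shown here, no measured step isolates the added chloro, so a small further move toward a lower number is expected, and no change beyond the scatter remains possible. The expected step is a 1.4-fold lower number from compound 2 to compound 3 (0.14 log units; within the scatter). In this assay, compound 3 is estimated at 1800 nM, with an expected range from 700 nM to 4500 nM.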

Compound 3, concentration for 50% growth inhibition: 6230 nM
Compound 3: middle estimate off by 3.5-fold (0.54 log units), on the low side; the measured number lies above the stated range.
By their numbers in this assay, from the lowest: compound 2; then compounds 1 and 3 (each within the scatter of the next).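

In this assay, the added chloro, placed ortho to a chloro group, reverses the earlier move toward a lower number: a 2.5-fold higher number from compound 2 to compound 3 (0.40 log units; beyond the scatter). The step is modest but beyond the scatter, so at this position the added chloro costs rather than helps, and the advantage of 4-chlorophenyl does not carry over to 3,4-dichlorophenyl, as a 1.1-fold higher number from compound 1 to compound 3 (0.02 log units; within the scatter) puts it level with the 2,3-dimethylphenyl of compound 1. No measurement at hand explains this step.

The compounds shown leave open whether the higher number belongs to the new chloro itself or to the two chloro groups together, which a 3-chlorophenyl group alone could separate. They also leave open whether a fluoro, a methoxy or an amine in the same place would shift the number the same way.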